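Notes on the series: aryl swap on the amine of compound 3

The source may report more compounds than this note shows. Statements on the series, on what has been measured and on what is new or still open speak of the compounds shown alone.

Measured so far in a functional assay on A549 cells (Homo sapiens) for antiproliferative activity, read by MTT assay, with a stated time of 72 h; a lower number here means a stronger inhibitor, a higher number a weaker inhibitor:
compound 1 `CC(C)OC1=C(C(=O)c2ccccc2)C(c2ccc(Br)cc2)N(CCCn2ccnc2)C1=O` gives 8720 nM
compound 2 `O=C(C1=C(OC2CCCCC2)C(=O)N(CCCn2ccnc2)C1c1ccc(Br)cc1)c1ccccc1` gives 31200 nM
compound 3 `O=C(C1=C(Nc2ccc(F)cc2)C(=O)N(CCCn2ccnc2)C1c1ccc(Br)cc1)c1ccccc1` gives 27400 nM

Compound 3 stands second highest of the three numbers. Its nearest neighbour is compound 2, and the pair is within the scatter (a 1.1-fold lower number from compound 2 to compound 3 (0.06 log units; within the scatter)); its furthest is compound 1, from which the step is a 3.1-fold higher number from compound 1 to compound 3 (0.50 log units; beyond the scatter). The remaining measured step is a 3.6-fold higher number from compound 1 to compound 2 (0.55 log units; beyond the scatter). All three steps change the group on the double-bonded ring carbon; none touches the substituent on the aryl ring of the amine.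

Compound 4 `O=C(C1=C(Nc2ccccc2Br)C(=O)N(CCCn2ccnc2)C1c1ccc(Br)cc1)c1ccccc1` differs from compound 3 by 2-bromophenyl in place of 4-fluorophenyl on an amine nitrogen. Among the compounds with values here, no measured step bears on this change; the amine variant is represented by compound 3 alone. With nothing in the data to set a direction, the expectation for this assay is a step that stays within the scatter, a 1.1-fold lower number from compound 3 to compound 4 (0.04 log units; within the scatter). The estimate for compound 4 is therefore 25000 nM, expected to fall between 9000 nM and 70000 nM.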

Compound 4, half-maximal inhibitory concentration: 20100 nM
Compound 4: the middle estimate sits 1.2-fold (0.09 log units) above what was measured; low and high end bracket the measured number.
By their numbers in this assay, from the lowest: compound 1; then compounds 4, 3 and 2 (each within the scatter of the next).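

In this assay the first read on the aryl group of the amine shows that 2-bromophenyl in place of 4-fluorophenyl stays within the scatter (a 1.4-fold lower number from compound 3 to compound 4 (0.13 log units; within the scatter)). The same holds for (2-bromophenyl)amino in place of cyclohexyloxy (a 1.6-fold lower number from compound 2 to compound 4 (0.19 log units; within the scatter)), whereas (2-bromophenyl)amino in place of isopropoxy is a step beyond the scatter (a 2.3-fold higher number from compound 1 to compound 4 (0.36 log units; beyond the scatter)), so compound 1 keeps the lowest number of the four. No evidence on any property of these groups bears on the result.

Compounds 3 and 4 change the halogen and its place on the aryl ring together, so the two remain unseparated. A 4-bromophenyl or a 2-fluorophenyl on the amine nitrogen would separate them, and an unsubstituted phenyl would show whether either halogen matters at all.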